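Benzyl in Place of Chlorophenyl: Expected Cytotoxicity

A few compounds are considered here, and "the series" means these few. Any claim that something is new, unique, unknown or untested is made for them only; others in the source may bear on it.

Compound 1: `CCC1(Cc2ccccc2)OS(=O)(=O)C=C1OCc1ccc(OC)cc1` — in an ADME assay on HEL cells (Homo sapiens) for cytotoxicity, with a stated time of 3 days (on this read-out lower numbers stand for higher toxicity in this test and higher numbers for lower toxicity in this test), compound 1 gives >= 200000 nM, a limit of the test rather than a number.
Compound 2: `CCC1(Cc2ccccc2)OS(=O)(=O)C=C1OCc1cccc(Cl)c1` — in this assay compound 2 gives >= 20000 nM, likewise a limit.

Compound 2 therefore stands only at a limit in this assay, as the limit of >= 20000 nM in this assay, at which 1 of the 2 values shown sits, shows. Going by the values given here, the one measured step, a step that the two limits leave unreadable from compound 1 to compound 2, cannot be read in size, so it offers no guide in either direction. Compound 3 is `CCC1(Cc2ccccc2)OS(=O)(=O)C=C1OCCc1ccccc1`, differing from compound 2 by benzyl in place of 3-chlorophenyl on a saturated chain carbon bound to an oxygen on an unsaturated carbon. No step beyond the scatter is expected here; most likely another limit. Compound 3 is expected to give 50000 nM, roughly between 15000 nM and 250000 nM, an expected step that the limit leaves unreadable from compound 2 to compound 3.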

Compound 3, minimum cytotoxic concentration: >= 20000 nM
Compound 3 ended at the assay's limit (the forecaster's own chance of this, stated with the estimate: 75%); the middle value lies beyond the limit too.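

Compound 1, compound 2 and compound 3 all stand at limits in this assay, and the steps among them cannot be read in size. From the compounds shown here alone, the concentration at which any of them becomes toxic to these cells remains open.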